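Replacing a cyclohexylethyl amide group with a fluoromethoxybenzyl branch

The source may hold more compounds than are shown below. What is called first, only, known or untested is meant among the compounds shown, and "the series" means these compounds.

Measured compounds:
compound 1 `CC(C)C[C@H](N)c1cc(C(F)(F)F)ccc1N1CCN(C(=O)COc2ccc(O)cc2)CC1` — 4600 nM
compound 2 `CC(C)C[C@H](N)c1cc(C(F)(F)F)ccc1N1CCN(C(=O)CCC2CCCCC2)CC1` — 5700 nM
compound 3 `CC(C)C[C@H](N)c1cc(C(F)(F)F)ccc1N1CCN(C(=O)CC(C)C(=O)c2ccc(Cl)cc2)CC1` — 1100 nM

In an assay on HEK293 cells for displacement of a labelled ligand from Melanocortin receptor 4 (Homo sapiens) (on this read-out higher numbers stand for weaker inhibition and lower numbers for stronger inhibition), compound 2 gives the highest of the three numbers; compound 1 sits close to it, while compound 3 lies clearly lower. The unmeasured compound 4 `COc1ccc(CC(C)C(=O)N2CCN(c3ccc(C(F)(F)F)cc3[C@@H](N)CC(C)C)CC2)cc1F` differs from compound 2 only at the amide carbonyl: 1-(3-fluoro-4-methoxybenzyl)ethyl in place of 2-cyclohexylethyl on a carbonyl carbon.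

Within the data shown here, two measured steps bear on this. The exchange of groups at that same position between compound 1 and compound 2 changed little: a 1.2-fold higher number from compound 1 to compound 2 (0.09 log units; within the scatter). Moving to a branched chain carrying an aromatic ring, however, gave a 5.2-fold lower number from compound 2 to compound 3 (0.71 log units; beyond the scatter), and a similar change from compound 1 gave a 4.2-fold lower number from compound 1 to compound 3 (0.62 log units; beyond the scatter). Compound 4 likewise carries a branched chain with an aromatic ring, though without the second carbonyl of compound 3, so a modest lowering in this assay is expected, somewhat smaller than that seen for compound 3 because of a 5.2-fold lower number from compound 2 to compound 3 (0.71 log units; beyond the scatter) alone supporting it. The expected step is a 3.6-fold lower number from compound 2 to compound 4 (0.55 log units; beyond the scatter). Compound 4 is therefore estimated at 1600 nM, within a range of 500 nM to 4800 nM.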

Compound 4, inhibition constant: 200 nM
For compound 4 the middle estimate is 8.0-fold (0.90 log units) above the measured one; the whole stated range lies above it.
By their numbers in this assay, from the lowest: compound 4; then compound 3; then compounds 1 and 2 (each within the scatter of the next).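

At the amide carbonyl, the 1-(3-fluoro-4-methoxybenzyl)ethyl group gives the largest changes seen at this position in this assay, with a 29-fold lower number from compound 2 to compound 4 (1.45 log units; beyond the scatter) and a 23-fold lower number from compound 1 to compound 4 (1.36 log units; beyond the scatter), whereas the earlier exchanges there were at most modest. The same group also improves on the ketone-bearing chain, with a 5.5-fold lower number from compound 3 to compound 4 (0.74 log units; beyond the scatter), which shows that a low number in this set does not depend on the second carbonyl of compound 3. No measurement given here accounts for the size of these steps.

The compounds shown do not separate what the fluorine, the methoxy and the chain branch each contribute to the result for compound 4. Going by these compounds, how the number would respond to a nitrile in place of the fluorine, or to a hydroxyl in place of the methoxy, also remains open.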